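The source may hold more compounds than are shown below. What is called first, only, known or untested is meant among the compounds shown, and "the series" means these compounds.

In an ADME assay for permeability, using PAMPA, at pH 7.4 (a higher number here means that the compound crosses the layer faster, a lower number that the compound crosses the layer more slowly), compound 1 (`COc1ccc2[nH]c(C)c(Cc3ccccc3)c(=O)c2c1`) gives 188 10^-6 cm/s, compound 2 (`Cc1[nH]c2ccc(Cl)cc2c(=O)c1Cc1ccccc1`) gives 415 10^-6 cm/s and compound 3 (`COc1ccc2c(c1)c(=O)c(Cc1ccccc1)c(C)n2C`) gives 268 10^-6 cm/s. Compound 3 thus sits within the scatter of each of the other compounds, although those two are separated by a modest step beyond the scatter. Compound 4 (`Cc1c(Cc2ccccc2)c(=O)c2cc(Cl)ccc2n1C`) differs from compound 3 in one place: chloro in place of methoxy on an aromatic carbon.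

The same exchange has been measured once, as a 2.2-fold higher number from compound 1 to compound 2 (0.34 log units; beyond the scatter). The other measured step, methyl in place of hydrogen on an aromatic nitrogen, is a 1.4-fold higher number from compound 1 to compound 3 (0.15 log units; within the scatter), and it gives no sign that the exchange should behave differently on the methylated compounds. With a single precedent, transfer of that size remains uncertain, but a modest rise in this assay is the working expectation. The expected change is a 2.1-fold higher number from compound 3 to compound 4 (0.31 log units; beyond the scatter). For compound 4, the estimated value is 550 10^-6 cm/s, with an expected range from 320 10^-6 cm/s to 950 10^-6 cm/s.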

Compound 4, apparent permeability in the ADME assay: 489 10^-6 cm/s
Estimate against measurement, compound 4: 1.1-fold (0.05 log units) above; measured number inside the range.
By their numbers in the ADME assay, from the lowest: compounds 1, 3, 2 and 4 (each within the scatter of the next, the first and the last beyond it).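

Within the data shown here, in the ADME assay, chloro in place of methoxy on this aromatic carbon can now be read on a second core, a 1.8-fold higher number from compound 3 to compound 4 (0.26 log units; within the scatter), and it agrees with the earlier step on the core of compound 1: the same change on two cores in the ADME assay, a 2.2-fold higher number (0.34 log units; beyond the scatter) from compound 1 to compound 2 and a 1.8-fold higher number (0.26 log units; within the scatter) from compound 3 to compound 4, 1.2-fold (0.08 log units) apart, within the scatter of two such steps In the ADME assay, methyl in place of hydrogen on the aromatic nitrogen can now also be read on the chloro compounds, a 1.2-fold higher number from compound 2 to compound 4 (0.07 log units; within the scatter), and the two readings of that change agree as well: the same change on two cores in the ADME assay, a 1.4-fold higher number (0.15 log units; within the scatter) from compound 1 to compound 3 and a 1.2-fold higher number (0.07 log units; within the scatter) from compound 2 to compound 4, 1.2-fold (0.08 log units) apart, within the scatter of two such steps The chloro exchange also shows a change that the earlier compounds did not show, in a physicochemical assay for solubility, read by HPLC, at pH 7.4; on this read-out lower numbers stand for lower solubility and higher numbers for higher solubility: the measured solubility of compound 3, 10000 nM, and of compound 4, 2000 nM, a 5.0-fold lower number (0.70 log units; beyond the scatter) In the physicochemical assay, compound 3 gives 10000 nM and compound 4 gives 2000 nM.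

Open, from the compounds shown here alone, is how the ADME assay and the physicochemical assay respond at this aromatic carbon to other groups, such as a nitrile or an amine. A single pair in the physicochemical assay also leaves open whether the lower number carries over to the core of compound 1.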